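Swapping a nitrophenyl arm for a pyridyl arm

This account rests on a few compounds, and the source may have more. Where it says the series, first, only, none or still open, it means among the compounds named here.

Measured so far:
compound 1, `COc1cc(C(=O)c2sc(-c3ccc(Br)cc3)cc2N)cc(OC)c1OC`, 92 nM
compound 2, `COc1cc(C(=O)c2sc(-c3ccc([N+](=O)[O-])cc3)cc2N)cc(OC)c1OC`, 110 nM
compound 3, `COc1cc(C(=O)c2sc(-c3ccc(I)cc3)cc2N)cc(OC)c1OC`, 190 nM

These three share one core and differ only in the group carried by the aromatic arm. In a functional assay on MOLT-4 cells (Homo sapiens) for antiproliferative activity (a higher number here means a weaker inhibitor, a lower number a stronger inhibitor), compound 2 gives 110 nM, which places it second highest of the three numbers; its nearest neighbour is compound 1, its furthest compound 3, and both gaps lie within the scatter.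

Compound 4, `COc1cc(C(=O)c2sc(-c3ccncc3)cc2N)cc(OC)c1OC`, has not been measured. It differs from compound 2 in one place: pyridin-4-yl in place of 4-nitrophenyl on an aromatic carbon.

The measured steps swap one small group for another on the same arm: a 1.2-fold higher number from compound 1 to compound 2 (0.08 log units; within the scatter), a 2.1-fold higher number from compound 1 to compound 3 (0.31 log units; beyond the scatter) and a 1.7-fold higher number from compound 2 to compound 3 (0.24 log units; within the scatter). None of them replaces the whole arm, so none bears directly on the change to compound 4; they only show that small changes on this arm moved the number little. With no closer guide, the step of a 2.3-fold higher number from compound 2 to compound 4 (0.36 log units; beyond the scatter) is expected to be modest and towards a higher number, with wide uncertainty. For compound 4 the estimate is 250 nM, in the range 80 nM to 800 nM.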

Compound 4, half-maximal inhibitory concentration: 88 nM
The estimate for compound 4 lay 2.8-fold (0.45 log units) above the measured number; low and high end bracket the measured number.
By their numbers in this assay, from the lowest: compounds 4, 1, 2 and 3 (each within the scatter of the next, the first and the last beyond it).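

In this assay, replacing the whole arm, not just a small group on it, gives a 1.3-fold lower number from compound 2 to compound 4 (0.10 log units; within the scatter) and a 1.0-fold lower number from compound 1 to compound 4 (0.02 log units; within the scatter) and both steps lie within the scatter. So on the aromatic carbon next to the ring sulfur, a pyridin-4-yl arm, which has a hetero atom in its ring and no added group, serves about as well as the 4-nitrophenyl and 4-bromophenyl arms. Among these compounds, the only step beyond the scatter is a 2.2-fold lower number from compound 3 to compound 4 (0.33 log units; beyond the scatter) and it is modest, while nothing measured here explains how the arm can change this much with so little effect on the number.

On these data alone, it remains open whether a non-aromatic arm such as piperidin-4-yl would stay in this range. The same question applies to a phenyl arm carrying a carboxylic acid or an amine.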